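A few compounds are considered here, and "the series" means these few. Any claim that something is new, unique, unknown or untested is made for them only; others in the source may bear on it.

Measured in a functional assay on SK-OV-3 cells (Homo sapiens) for cytotoxicity, read by MTT assay, with a stated time of 48 h; a higher number here means a weaker inhibitor, a lower number a stronger inhibitor:

compound 1, `CN(C)CCN1CCN(C2=Nc3ccccc3C(CC(=O)NCc3ccccc3)N2c2ccc(-c3ccccc3)cc2)CC1`: 1970 nM
compound 2, `CN(C)CCN1CCN(C2=Nc3ccccc3C(CC(=O)NCc3ccc(F)cc3)N2c2ccc(-c3ccccc3)cc2)CC1`: 3090 nM
compound 3, `CN(C)CCN1CCN(C2=Nc3ccccc3C(CC(=O)NCc3ccccn3)N2c2ccc(-c3ccccc3)cc2)CC1`: 5080 nM

Compound 3 gives the highest number of the three. Its nearest neighbour is compound 2, and the step of a 1.6-fold higher number from compound 2 to compound 3 (0.22 log units; within the scatter) stays within the scatter. Compound 1 lies furthest from it: the step of a 2.6-fold higher number from compound 1 to compound 3 (0.41 log units; beyond the scatter) is the only one here that goes beyond the scatter, and it is a modest one. The other step, a 1.6-fold higher number from compound 1 to compound 2 (0.20 log units; within the scatter), is within the scatter.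

Compound 4, `CN(C)CCN1CCN(C2=Nc3ccccc3C(CC(=O)NCc3ccncc3)N2c2ccc(-c3ccccc3)cc2)CC1`, is not yet measured in this assay. It differs from compound 3 in one place: pyridin-4-yl in place of pyridin-2-yl on a saturated chain carbon bound to an amide-type nitrogen. Among the compounds with values here, both measured steps that touch this position exchange one ring for another of a different kind, and of these only the step from compound 1 to compound 3 moves the number beyond the scatter. Within the data shown here, no measured step moves the nitrogen within a pyridine ring, so nothing on record shows how that reads here. Compound 4 is therefore expected to give a number close to that of compound 3, with the step of a 1.0-fold lower number from compound 3 to compound 4 (0.01 log units; within the scatter) estimated to lie within the scatter. The estimate for compound 4 in this assay is 5000 nM, within a range of 2000 nM to 12000 nM.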

Compound 4, half-maximal inhibitory concentration: 11700 nM
Compound 4: middle estimate off by 2.3-fold (0.37 log units), on the low side; low and high end bracket the measured number.
By their numbers in this assay, from the lowest: compounds 1, 2 and 3 (each within the scatter of the next, the first and the last beyond it); then compound 4.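

In this assay, within the data shown here, the change from pyridin-2-yl to pyridin-4-yl on a saturated chain carbon bound to an amide-type nitrogen gives a 2.3-fold higher number from compound 3 to compound 4 (0.36 log units; beyond the scatter), although the two groups have the same atoms and the same counts under the computed comparison; the earlier compounds exchanged only rings of different kinds, so this is the first sign that the place of the nitrogen within the pyridine ring can by itself move the number beyond the scatter. Pyridin-4-yl also stands further from the two carbocyclic groups than the earlier compounds showed, with a 3.8-fold higher number from compound 2 to compound 4 (0.58 log units; beyond the scatter) and a 5.9-fold higher number from compound 1 to compound 4 (0.77 log units; beyond the scatter), which makes compound 4 the weakest of the four in this series, since all three of its steps lie beyond the scatter. No measurement on record accounts for this difference between the two pyridine isomers.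

Going by these compounds, how pyridin-3-yl would read at this position remains open, and so does whether the order holds for a pyridine ring carrying a methoxy group or an amine. A longer chain between the ring and the amide nitrogen is also left open, as is any change elsewhere on the shared core.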